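This account rests on a few compounds, and the source may have more. Where it says the series, first, only, none or still open, it means among the compounds named here.

Measured so far in a functional assay on K562 cells (Homo sapiens) for inhibition, read by MTT assay, with a stated time of 48 h; on this read-out higher numbers stand for weaker inhibition and lower numbers for stronger inhibition:
compound 1, `Cc1ccc(NC(=O)c2ccc(F)cc2)cc1-n1cc(-c2cccnc2)cn1`: 12500 nM
compound 2, `Cc1ccc(NC(=O)c2ccc(CN3CCN(C)CC3)cc2)cc1-n1cc(-c2cccnc2)cn1`: 1670 nM
compound 3, `CCN(CC)Cc1ccc(C(=O)Nc2ccc(C)c(-n3cc(-c4cccnc4)cn3)c2)cc1`: 3260 nM

Compound 3 stands second highest of the three numbers. Its nearest neighbour is compound 2, and the step of a 2.0-fold higher number from compound 2 to compound 3 (0.29 log units; within the scatter) stays within the scatter, so the two cannot be ordered. Its furthest neighbour is compound 1, and the step of a 3.8-fold lower number from compound 1 to compound 3 (0.58 log units; beyond the scatter) lies beyond the scatter.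

Compound 4, `Cc1ccc(NC(=O)c2ccc(CN3CCCN(C)CC3)cc2)cc1-n1cc(-c2cccnc2)cn1`, differs from compound 3 by 4-methyl-1,4-diazepan-1-yl in place of diethylamino on a saturated chain carbon bound to an aromatic carbon. Within the data shown here, two measured steps bear on this. First, the step of a 2.0-fold higher number from compound 2 to compound 3 (0.29 log units; within the scatter) shows that exchanging the diethylamino for a cyclic diamine of closely related make-up moves the number only within the scatter. Second, the steps of a 7.5-fold lower number from compound 1 to compound 2 (0.87 log units; beyond the scatter) and a 3.8-fold lower number from compound 1 to compound 3 (0.58 log units; beyond the scatter) show that both amine-bearing side chains sit well below the fluoro compound, and by similar amounts. The change into compound 4 therefore reads as another variation among such side chains rather than a move of the kind seen from compound 1. The expected step of a 1.6-fold lower number from compound 3 to compound 4 (0.21 log units; within the scatter) is small, tending to the lower side, and within the scatter. Compound 4 is accordingly estimated at 2000 nM, with a range from 800 nM to 5000 nM.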

Compound 4, half-maximal inhibitory concentration: 8650 nM
Beside the measured number, compound 4's estimate is 4.3-fold (0.64 log units) below it; measured number above the stated range.
By their numbers in this assay, from the lowest: compounds 2 and 3 (each within the scatter of the next); then compounds 4 and 1 (each within the scatter of the next).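

Working from this assay, the amine on the saturated chain carbon bound to an aromatic carbon now proves to matter, since exchanges at this place are no longer confined to the scatter: a 2.7-fold higher number from compound 3 to compound 4 (0.42 log units; beyond the scatter) and a 5.2-fold higher number from compound 2 to compound 4 (0.71 log units; beyond the scatter) both lie beyond it. The closely related 4-methylpiperazin-1-yl and 4-methyl-1,4-diazepan-1-yl are therefore not interchangeable here, although 4-methylpiperazin-1-yl and diethylamino could not be ordered. The earlier pattern of an amine-bearing side chain in place of fluoro giving a lower number holds for compound 2 and compound 3, but the 4-methyl-1,4-diazepan-1-yl side chain goes against it, with a 1.4-fold lower number from compound 1 to compound 4 (0.16 log units; within the scatter) staying within the scatter; no supporting measurement bears on these differences.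

The compounds shown leave open whether the seven-membered ring or some other feature of 4-methyl-1,4-diazepan-1-yl sets this compound apart, which a pyrrolidine, a morpholine or a piperazine without the methyl group could help to separate. Also open, on these data alone, is how a longer chain between the aromatic carbon and the amine would read at this place.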